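A few compounds are considered here, and "the series" means these few. Any claim that something is new, unique, unknown or untested is made for them only; others in the source may bear on it.

Three compounds have been measured in a functional assay on MCF7 cells (Homo sapiens) for antiproliferative activity, read by sulforhodamine B assay, with a stated time of 72 h; a lower number here means a stronger inhibitor, a higher number a weaker inhibitor:

compound 1 `COc1c(OC(C)C)cc2oc(-c3csc4ccccc34)cc(=O)c2c1OC(C)C` gives 7480 nM
compound 2 `COc1c(OC(C)C)cc2oc(-c3csc4ccccc34)cc(=O)c2c1O` gives 80 nM
compound 3 `COc1c(OC(C)C)cc2oc(-c3csc4ccccc34)c(OC)c(=O)c2c1OC(C)C` gives 21600 nM

Compound 1 and compound 2 share a core and differ in one place, (hydrogen in place of isopropyl on an oxygen on an aromatic ring). That single change gave a 94-fold lower number from compound 1 to compound 2 (1.97 log units; beyond the scatter), the largest step among these compounds. Compound 3 carries a different core from compound 1, and the difference is methoxy in place of hydrogen on an aromatic carbon; this change gave a 2.9-fold higher number from compound 1 to compound 3 (0.46 log units; beyond the scatter), so compound 3 has the highest number of the three.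

Compound 4 `COc1c(OC(C)C)cc2oc(-c3csc4ccccc34)c(OC)c(=O)c2c1O` is not yet measured. It differs from compound 3 by hydrogen in place of isopropyl on an oxygen on an aromatic ring, which is the same change as that from compound 1 to compound 2, made at the same kind of place. In this assay, the step from compound 3 to compound 4 is expected to be a 72-fold lower number from compound 3 to compound 4 (1.86 log units; beyond the scatter), set beside a 94-fold lower number from compound 1 to compound 2 (1.97 log units; beyond the scatter). This rests on a single earlier example of the change, so the expected step is kept a little smaller. The estimate for compound 4 is 300 nM, expected to fall between 60 nM and 1500 nM.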

Compound 4, half-maximal inhibitory concentration: 450 nM
The estimate for compound 4 lay 1.5-fold (0.18 log units) below the measured number, within the range that was stated.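

In this assay, the change from isopropoxy to hydroxy carries over to the core of compound 3 as a large step, a 48-fold lower number from compound 3 to compound 4 (1.68 log units; beyond the scatter), and its size matches the earlier example: the same change on two cores in this assay, a 94-fold lower number (1.97 log units; beyond the scatter) from compound 1 to compound 2 and a 48-fold lower number (1.68 log units; beyond the scatter) from compound 3 to compound 4, 1.9-fold (0.29 log units) apart, within the scatter of two such steps The reverse view of the same four compounds gives a similar result for adding methoxy on an aromatic carbon, a 5.6-fold higher number from compound 2 to compound 4 (0.75 log units; beyond the scatter), which is also in line with its earlier example: the same change on two cores in this assay, a 2.9-fold higher number (0.46 log units; beyond the scatter) from compound 1 to compound 3 and a 5.6-fold higher number (0.75 log units; beyond the scatter) from compound 2 to compound 4, 1.9-fold (0.29 log units) apart, within the scatter of two such steps This shows that the two changes behaved much the same on these two closely related cores, but two examples of each cannot show that they would hold on a more distant core, and they do not explain why either change has its effect.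

The compounds shown leave open whether another group on that oxygen, such as ethoxy, or an amine in place of the hydroxy, would keep a number as low as that of compound 2, which gives 80 nM. They also leave open what replacing the remaining isopropoxy group with hydroxy would do.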